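Aryl variation on the double-bonded chain: HeLa growth inhibition

The source may report more compounds than this note shows. Statements on the series, on what has been measured and on what is new or still open speak of the compounds shown alone.

Measured so far in an ADME assay on HeLa cells (Homo sapiens) for cytotoxicity, read by MTT assay, with a stated time of 72 h; a lower number here means a stronger inhibitor of growth, a higher number a weaker inhibitor of growth:
compound 1 `O=C(/C=C\c1ccccc1O)N1N=C(c2ccncc2)OC1c1c[nH]c2ccccc12`: 26.8 ug/mL
compound 2 `Cc1ccc(/C=C\C(=O)N2N=C(c3ccncc3)OC2c2c[nH]c3ccccc23)cc1`: > 30 ug/mL, which is a limit of the assay and not a number
compound 3 `O=C(/C=C\c1ccc(Cl)cc1Cl)N1N=C(c2ccncc2)OC1c1c[nH]c2ccccc12`: 29.3 ug/mL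

Compound 1 holds the lowest of the two numbers shown in this assay; its nearest neighbour is compound 3, with a 1.1-fold higher number from compound 1 to compound 3 (0.04 log units; within the scatter). Compound 2 sits at the assay ceiling, (the limit of > 30 ug/mL in this assay, at which 1 of the 3 values shown sits). The step of an at least 1.1-fold higher number from compound 1 to compound 2 (0.04 log units; that floor lies within the scatter) and the step of an at least 1.0-fold lower number from compound 2 to compound 3 (0.01 log units; that floor lies within the scatter) are likewise within the scatter, so the three aryl groups on the double-bonded chain carbon have not separated from one another.

Compound 4 `O=C(/C=C/c1c(Cl)cccc1Cl)N1N=C(c2ccncc2)OC1c1c[nH]c2ccccc12` is not yet measured. It differs from compound 1 as follows: 2-(2,6-dichlorophenyl)ethenyl in place of 2-(2-hydroxyphenyl)ethenyl on a carbonyl carbon. The closest measured step is the one to the 2,4-dichlorophenyl analogue, a 1.1-fold higher number from compound 1 to compound 3 (0.04 log units; within the scatter), which was flat, and the 4-methylphenyl step an at least 1.1-fold higher number from compound 1 to compound 2 (0.04 log units; that floor lies within the scatter) gave no change beyond the scatter either. For compound 4 the expected step is therefore a 1.1-fold higher number from compound 1 to compound 4 (0.03 log units; within the scatter), that is, no change beyond the scatter in either direction. Compound 4 is estimated at 29 ug/mL in this assay, with a range from 17 ug/mL to 48 ug/mL, and a fair chance that only a limit is reported.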

Compound 4, concentration for 50% growth inhibition: > 30 ug/mL
Compound 4: a limit, no number; the forecaster's own chance of this, stated with the estimate: 35%; middle value at least 1.0-fold (0.01 log units) away from the limit.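

In this assay compound 4 gives only a limit and not a number, and the series now has a second compound of this kind: the limit of > 30 ug/mL in this assay, at which 2 of the 4 values shown sit.

From the compounds shown here alone, replacing 2-(2-hydroxyphenyl)ethenyl on the carbonyl carbon with 2-(2,6-dichlorophenyl)ethenyl gives an at least 1.1-fold higher number from compound 1 to compound 4 (0.04 log units; that floor lies within the scatter), and the change from 2-(2,4-dichlorophenyl)ethenyl to the same group gives an at least 1.0-fold higher number from compound 3 to compound 4 (0.01 log units; that floor lies within the scatter), so a second dichlorophenyl pattern has not separated from the groups before it, although both steps are only floors and their true size remains unknown. Compound 2 and compound 4 both carry limits, and the step between them cannot be read.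

Still open, going by these compounds, is how far compound 2 and compound 4 lie from compound 1 and compound 3, and whether any group at this position can move the read-out beyond the scatter. The compounds shown also leave open what a dimethylamino or carboxylic acid group on the phenyl ring, or a longer chain in place of ethenyl, would do in this assay.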